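Cytotoxicity of one more ester on a shared core

The source may report more compounds than this note shows. Statements on the series, on what has been measured and on what is new or still open speak of the compounds shown alone.

Values in an ADME assay on HepG2 2.2.15 cells (Homo sapiens) for cytotoxicity (on this read-out higher numbers stand for lower toxicity in this test and lower numbers for higher toxicity in this test), for the three measured esters:
- compound 1 (`CC(=O)OCCc1c(-c2ccccc2Cl)c2cc(Cl)ccc2[nH]c1=O`) with 27000 nM
- compound 2 (`CCCCCCCC(=O)OCCc1c(-c2ccccc2Cl)c2cc(Cl)ccc2[nH]c1=O`) with 78000 nM
- compound 3 (`CC(=O)NCC(=O)OCCc1c(-c2ccccc2Cl)c2cc(Cl)ccc2[nH]c1=O`) with 110000 nM

Compound 3 stands at the upper end of these three numbers. The comparison a 1.4-fold higher number from compound 2 to compound 3 (0.15 log units; within the scatter) leaves it level with the hexyl-bearing ester, while a 4.1-fold higher number from compound 1 to compound 3 (0.61 log units; beyond the scatter) places it clear of the simple acetate.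

Compound 4 (`CC12CCC(C(=O)OCCc3c(-c4ccccc4Cl)c4cc(Cl)ccc4[nH]c3=O)(OC1=O)C2(C)C`) keeps the shared core and changes only the group on a carbonyl carbon (a group of 11 heavy atoms (9 carbon, 2 oxygen; one five-membered non-aromatic ring of carbon only, one five-membered non-aromatic ring with 1 hetero atom) in place of a group of 5 heavy atoms (3 carbon, 1 nitrogen, 1 oxygen; no ring), on a carbonyl carbon) so that a group of 11 heavy atoms with two five-membered non-aromatic rings takes the place of acetamidomethyl.

Within the data shown here, two measured steps bear on this change, both modest and both starting from the acetate: a 2.9-fold higher number from compound 1 to compound 2 (0.46 log units; beyond the scatter) with hexyl and a 4.1-fold higher number from compound 1 to compound 3 (0.61 log units; beyond the scatter) with acetamido. Two very different additions thus ended level with each other. None of the three measured compounds carries a ring in this group, so the data reach the new group only by extrapolation.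

In this assay, from the compounds shown here alone, no move beyond the scatter is expected, and the direction stays open. The estimated step is a 1.5-fold lower number from compound 3 to compound 4 (0.17 log units; within the scatter) and it rests on that level pair. The estimate for compound 4 is 75000 nM with an expected range from 30000 nM to 170000 nM in this read-out.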

Compound 4, half-maximal cytotoxic concentration: > 1800000 nM
Compound 4 was reported as a limit; the forecaster's own chance of this, stated with the estimate: 12%; middle value at least 24-fold (1.38 log units) away from the limit.
By their numbers in this assay, from the lowest: compound 1; then compounds 2 and 3 (each within the scatter of the next). At a limit, above all of these: compound 4.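

Compound 4 is reported in this assay only as a limit, not as a number: the limit of > 1800000 nM in this assay, at which 1 of the 4 values shown sits.

Even read as a limit, the change on this carbonyl carbon gives an at least 16-fold higher number from compound 3 to compound 4 (1.21 log units; beyond the scatter), along with an at least 23-fold higher number from compound 2 to compound 4 (1.36 log units; beyond the scatter) and an at least 66-fold higher number from compound 1 to compound 4 (1.82 log units; beyond the scatter), and all three steps are large. Among these compounds, the open-chain groups of compounds 1, 2 and 3 had moved the read-out only modestly, or not beyond the scatter, so this position proves able to carry a far larger shift than those compounds showed, and the shift appears with the one group here that contains rings.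

The true size of these steps stays unknown, since the limit fixes only one side of them, and the single change brings in both five-membered rings together with the extra heavy atoms, so the compounds shown cannot say which part matters. A plain cyclopentyl group, a single lactone ring, or an open chain of the same heavy-atom count carrying an ether oxygen on this carbonyl carbon would be needed to separate those parts.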